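From Amino to Acetamido on Compound 3

The source may report more compounds than this note shows. Statements on the series, on what has been measured and on what is new or still open speak of the compounds shown alone.

In a functional assay on aorta (Rattus norvegicus, strain Sprague-Dawley) (on this read-out lower numbers stand for an effect already at smaller amounts and higher numbers for an effect only at larger amounts of compound), compound 3 (`Cc1nn(-c2ccccc2)c2nc(OCc3ccccc3F)c(-c3nc(N)c(N)c(N)n3)cc12`) gives 960 nM and stands level with compound 2 (`Cc1nn(-c2ccccc2)c2nc(OCc3ccccc3F)c(-c3nc(N)c(N(C)C)c(N)n3)cc12`), which gives 1100 nM on the same scale. The gap between them is a 1.1-fold lower number from compound 2 to compound 3 (0.06 log units; within the scatter) and separates neither. Compound 1 (`Cc1nn(-c2ccccc2)c2nc(OCc3ccccc3F)c(-c3nc(N)c(N4CCCC4)c(N)n3)cc12`) stands apart on the high side at 12700 nM and is the only outlier of the three.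

Compound 4 (`CC(=O)Nc1c(N)nc(-c2cc3c(C)nn(-c4ccccc4)c3nc2OCc2ccccc2F)nc1N`) carries acetyl in place of hydrogen on a nitrogen on an aromatic ring, which turns amino to acetamido (acetyl in place of hydrogen on a nitrogen on an aromatic ring) on the shared core. The measured steps all concern this same group. Compound 2 and compound 3 show no step beyond the scatter, while a 12-fold lower number from compound 1 to compound 2 (1.06 log units; beyond the scatter) and a 13-fold lower number from compound 1 to compound 3 (1.12 log units; beyond the scatter) are both large. For the measured compounds named here, no measured compound has acetyl on that nitrogen, so these steps only bracket the outcome. A moderate move toward a higher number is expected, and the estimated step is a 2.6-fold higher number from compound 3 to compound 4 (0.42 log units; beyond the scatter) in this assay overall. Compound 4 is expected at 2500 nM with an estimated range from 700 nM to 9000 nM in this assay for now.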

Compound 4, half-maximal effective concentration: 930 nM
For compound 4 the middle estimate is 2.7-fold (0.43 log units) above the measured one; measured number inside the range.
By their numbers in this assay, from the lowest: compounds 4, 3 and 2 (each within the scatter of the next); then compound 1.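

In this assay, putting acetyl on this nitrogen gives a 1.0-fold lower number from compound 3 to compound 4 (0.01 log units; within the scatter) so the amino group can carry acetyl with no shift beyond the scatter. The same level holds against dimethylamino, with a 1.2-fold lower number from compound 2 to compound 4 (0.07 log units; within the scatter) and so acetamido, amino and dimethylamino cannot be told apart at this position on the shared core. Pyrrolidin-1-yl remains the only one of the four groups on the high side, with a 14-fold lower number from compound 1 to compound 4 (1.14 log units; beyond the scatter) as the step that separates it from acetamido.

The compounds shown leave open whether a benzoyl or methanesulfonyl group on this nitrogen would stay level too, and whether piperidin-1-yl or morpholin-4-yl at this position would go with pyrrolidin-1-yl on the high side. Nothing available explains why acetyl leaves the number level or why pyrrolidin-1-yl stands apart.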